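The compounds below may be only part of what the source reports. "The series", "measured", "known", "first", "only" and "open" are said of these compounds alone.

Measured so far:
- compound 1 `COc1ccc(-c2cc(C(=O)Nc3ccc(Oc4ccnc5[nH]ccc45)cc3)ncn2)cc1`: 9830 nM
- compound 2 `O=C(Nc1ccc(Oc2ccnc3[nH]ccc23)cc1)c1cc(-c2ccc(Br)cc2)ncn1`: 2610 nM

Of the compounds shown here, two share a core and have been tested in a functional assay on PC-3 cells (Homo sapiens) for cytotoxicity, read by MTT assay, with a stated time of 72 h; on this read-out lower numbers stand for stronger inhibition and higher numbers for weaker inhibition. Compound 1 gives 9830 nM, the higher of the two numbers, and compound 2 gives 2610 nM. Among the measured compounds shown here, the one change between them, bromo in place of methoxy on an aromatic carbon, brought a 3.8-fold lower number from compound 1 to compound 2 (0.58 log units; beyond the scatter).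

Compound 3 `COc1ccc(-c2cc(C(=O)Nc3ccc(Oc4ccnc5[nH]ccc45)c(F)c3)ncn2)cc1` is not yet measured. It differs from compound 1 by fluoro in place of hydrogen on an aromatic carbon, a fluoro in place of hydrogen on an aromatic carbon, placed ortho to a large group and meta to a large group on a six-membered aromatic ring of carbon only. For the measured compounds named here, the only measured step, that from compound 1 to compound 2, alters a different part of the molecule, the methoxy-bearing ring, and so gives no direct guide to a fluoro on the ring between the amide and the ether. With nothing in the data that speaks for or against it, compound 3 is expected to show a 1.5-fold lower number from compound 1 to compound 3 (0.18 log units; within the scatter) in this assay, an estimated step not beyond the scatter. Compound 3 is therefore estimated at 6500 nM, with a range from 2000 nM to 20000 nM.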

Compound 3, half-maximal inhibitory concentration: 2570 nM
For compound 3 the middle estimate is 2.5-fold (0.40 log units) above the measured one, within the range that was stated.
By their numbers in this assay, from the lowest: compounds 3 and 2 (each within the scatter of the next); then compound 1.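

In this assay, one fluoro in place of hydrogen, on an aromatic carbon of a six-membered aromatic ring of carbon only, ortho to a large group and meta to a large group, brought a 3.8-fold lower number from compound 1 to compound 3 (0.58 log units; beyond the scatter). The step is modest, yet it shows what the bromo for methoxy change could not: this second place in the molecule also responds, and a substituent of just 1 heavy atom, replacing a hydrogen, is enough to move the number beyond the usual scatter. Nothing among the available data explains why this small change has such an effect, so the result stands as an observation without a cause.

A single substituent at this place cannot show whether the step is particular to fluoro or would also appear with chloro, methyl or an amine there. It also remains open whether fluoro at this place and bromo in place of methoxy would add up in one molecule, since no compound shown carries both changes.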